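The source may hold more compounds than are shown below. What is called first, only, known or untested is meant among the compounds shown, and "the series" means these compounds.

Compound 1 `O=C(Nc1cccc(-c2oc3cc(-c4ccc(F)cc4)ccc3c(=O)c2O)c1)c1ccccc1F` gives 10100 nM in a functional assay on HepG2 cells (Homo sapiens) for antiproliferative activity, read by CCK-8 assay, with a stated time of 72 h; a lower number here means a stronger inhibitor, a higher number a weaker inhibitor. Its number is the smallest of the three shown, yet neither neighbour stands apart from it: compound 3 `O=C(Nc1cccc(-c2oc3cc(-c4ccc(F)cc4)ccc3c(=O)c2O)c1)c1ccc(Br)cc1` gives 13900 nM and compound 2 `Cc1ccccc1C(=O)Nc1cccc(-c2oc3cc(-c4ccc(F)cc4)ccc3c(=O)c2O)c1` gives 19400 nM, with a 1.4-fold higher number from compound 1 to compound 3 (0.14 log units; within the scatter) and a 1.9-fold higher number from compound 1 to compound 2 (0.28 log units; within the scatter). Compound 4 `COc1cccc(C(=O)Nc2cccc(-c3oc4cc(-c5ccc(F)cc5)ccc4c(=O)c3O)c2)c1` differs from compound 1 by 3-methoxyphenyl in place of 2-fluorophenyl on a carbonyl carbon. For the measured compounds named here, the steps that bear on this exchange of the aryl on the carbonyl carbon are a 1.4-fold higher number from compound 1 to compound 3 (0.14 log units; within the scatter) and a 1.4-fold lower number from compound 2 to compound 3 (0.14 log units; within the scatter), both within the scatter, so no step beyond the scatter is expected here: a 1.2-fold higher number from compound 1 to compound 4 (0.07 log units; within the scatter). Compound 4 is therefore estimated in this assay at 12000 nM, with a range of 6000 nM to 25000 nM.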

Compound 4, half-maximal inhibitory concentration: 9950 nM
Compound 4: middle estimate off by 1.2-fold (0.08 log units), on the high side; the measured number falls inside the stated range.
By their numbers in this assay, from the lowest: compounds 4, 1, 3 and 2 (each within the scatter of the next).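

In this assay, 3-methoxyphenyl on the carbonyl carbon brings a hydrogen-bond acceptor that 2-fluorophenyl lacks, yet the steps stay small (a 1.0-fold lower number from compound 1 to compound 4 (0.01 log units; within the scatter); a 1.4-fold lower number from compound 3 to compound 4 (0.15 log units; within the scatter); a 1.9-fold lower number from compound 2 to compound 4 (0.29 log units; within the scatter)). The four aryl groups at this position therefore remain within the scatter of one another, and this exchange separates none of them. Nothing available explains this flat response.

Still open, on these data alone, is whether any change here can move the number beyond the scatter. An amine, a carboxylic acid or a longer chain in place of the aryl group would test this.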